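The compounds below may be only part of what the source reports. "The series", "measured", "known", "first", "only" and "open" are said of these compounds alone.

Measured compounds:

Compound 1, `O=C(COc1ccc(C(=O)/C=C/c2ccccc2Cl)cc1)N[C@H]1CCOC1=O`: in a functional assay on MCF7 cells (Homo sapiens) for antiproliferative activity, read by MTT assay, with a stated time of 72 h (on this read-out lower numbers stand for stronger inhibition and higher numbers for weaker inhibition), compound 1 gives 17400 nM.
Compound 2, `O=C(CNc1ccccc1F)N[C@H]1CCOC1=O`: compound 2 reaches only a limit of the assay, > 64000 nM.
Compound 3, `O=C(CNc1ccc(Cl)cc1Cl)N[C@H]1CCOC1=O`: compound 3 likewise reaches only a limit of the assay, > 64000 nM.

Within the data shown here, compound 1 is thus the only compound of the three with an actual number in this assay; the other two sit at the limit of > 64000 nM in this assay, at which 2 of the 3 values shown sit, so no step between measured compounds can be drawn, and nothing here tells how large a change of one group typically shifts the read-out.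

Compound 4, `O=C(COc1ccc(C(=O)/C=C/c2ccccc2Br)cc1)N[C@H]1CCOC1=O`, shares the core of compound 1 and differs from it in one place: bromo in place of chloro on an aromatic carbon. The exchange is on an aromatic carbon of a six-membered aromatic ring of carbon only, ortho to a large group, and it brings in one heavy atom for one heavy atom, with no ring, no donor, no acceptor and no charge gained or lost. Among the measured compounds shown here, with no measured step to lean on, the size of the move is expected to be small: none beyond the scatter of this assay, in either direction.

Compound 4 is therefore estimated at 15000 nM, within a range of 6000 nM to 40000 nM, which corresponds to an expected step of a 1.2-fold lower number from compound 1 to compound 4 (0.06 log units; within the scatter).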

Compound 4, half-maximal inhibitory concentration: 15300 nM
Compound 4: the middle estimate sits 1.0-fold (0.01 log units) below what was measured; the measured number falls inside the stated range.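

In this assay, among these compounds, the exchange of chloro for bromo on an aromatic carbon, ortho to a large group, is the first step that can be read, and it gives a 1.1-fold lower number from compound 1 to compound 4 (0.06 log units; within the scatter) within the shared core. At this place, then, the read-out does not tell the 2-chlorophenyl group from the 2-bromophenyl group, and this one exchange of one heavy atom for another leaves compound 4 with a measured number in the same range as compound 1. Nothing shown here bears on why the two compounds match.

This single step leaves open how the read-out responds at this place to a group of another kind, such as an amine, a methoxy group or a carboxylic acid, and whether the same exchange would read alike on another carbon of this ring. Any steps involving compound 2 and compound 3 cannot be read: the limit of > 64000 nM in this assay, at which 2 of the 4 values shown sit.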